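The source may report more compounds than this note shows. Statements on the series, on what has been measured and on what is new or still open speak of the compounds shown alone.

Measured compounds:
- compound 1: `COc1ccc(C(=O)Nc2ccccc2Cl)cc1OC1CCCC1` — 190 nM
- compound 2: `COc1ccc(C(=O)Nc2c(F)cccc2F)cc1OC1CCCC1` — 70 nM
- compound 3: `COc1ccc(C(=O)Nc2c(F)cccc2Cl)cc1OC1CCCC1` — 240 nM

In an assay on isolated protein for inhibition of phosphodiesterase 4A (Sus scrofa) (a higher number here means a weaker inhibitor, a lower number a stronger inhibitor), compound 1 stands second highest of the three numbers. Its nearest neighbour is compound 3, reached by a 1.3-fold higher number from compound 1 to compound 3 (0.10 log units; within the scatter), a step within the scatter. Its furthest is compound 2, reached by a 2.7-fold lower number from compound 1 to compound 2 (0.43 log units; beyond the scatter). Between the other two, a 3.4-fold higher number from compound 2 to compound 3 (0.54 log units; beyond the scatter). All three measured changes sit on the ring that carries the amide nitrogen; the rest of the shared core is the same in every measured compound.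

Compound 4 is `COc1ccc(C(=O)Nc2ccccc2Cl)cc1OC`. Compared with compound 1, the change is methyl in place of cyclopentyl on an oxygen on an aromatic ring. For the measured compounds named here, no measured step touches this oxygen, so none of them bears on the change; the data give no direct guide here.

The change removes a five-membered ring that every measured compound keeps. The number for compound 4 is expected to move more than any measured step, and the estimate for it is 2000 nM (range 200 nM to 20000 nM). This estimate means a step of an 11-fold higher number from compound 1 to compound 4 (1.02 log units; beyond the scatter), expected as a weaker inhibitor.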

Compound 4, half-maximal inhibitory concentration: 650 nM
Estimate against measurement, compound 4: 3.1-fold (0.49 log units) above; measured number inside the range.
By their numbers in this assay, from the lowest: compound 2; then compounds 1 and 3 (each within the scatter of the next); then compound 4.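

In this assay, the oxygen on the aromatic ring now has a measured step of its own, the change from cyclopentyloxy to methoxy giving a 3.4-fold higher number from compound 1 to compound 4 (0.53 log units; beyond the scatter). For the compounds shown here, this shows that the group on this oxygen affects inhibition, which the earlier compounds could not show because they all carry cyclopentyl there. It also shows that the five-membered ring is not required for measurable inhibition, since compound 4 keeps only a methyl there and the step is modest. Nothing available here explains the loss.

Still open, on these data alone, is where between methyl and cyclopentyl the number changes, for example with an ethyl group or an isopropyl group, and how a larger group such as cyclohexyl would behave. As far as these compounds go, it is also open whether the same change would give a step of similar size on the 2,6-difluorophenyl amide of compound 2.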